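Sulfone and sulfide enones against prostate cancer cell growth

The source may hold more compounds than are shown below. What is called first, only, known or untested is meant among the compounds shown, and "the series" means these compounds.

Three compounds were tested in a functional assay on DU-145 cells (Homo sapiens) for inhibition, read by trypan blue exclusion, with a stated time of 96 h; a lower number here means a stronger inhibitor of growth, a higher number a weaker inhibitor of growth. Each carries a carbonyl joined to a halogenated phenyl ring, a double-bonded carbon chain bearing an aromatic group, and a sulfur substituent on the chain.

Compound 1 `Cc1ccc(S/C(=C/c2cnc3ccccc3c2)C(=O)c2ccc(Cl)cc2)cc1` stands apart: in this assay it reaches only a limit, > 100000 nM, and so gives no number. Compound 2 `Cc1cc(C)cc(/C=C(\C(=O)c2ccc(Br)cc2)S(=O)(=O)Cc2ccc(F)cc2)c1` gives 10000 nM in this assay, the higher of the two numbers recorded. Compound 3 `O=C(/C(=C\c1ccc(Br)cc1)SCc1ccc(F)cc1)c1ccc(Cl)cc1` gives 9000 nM, and the two numbers lie within the usual scatter of each other, so no order between compound 2 and compound 3 can be read from them.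

Compound 4 `O=C(/C(=C\c1ccc(Br)cc1)S(=O)(=O)Cc1ccc(F)cc1)c1ccc(Br)cc1` has not yet been measured. Compared with compound 2 it differs in one place: 4-bromophenyl in place of 3,5-dimethylphenyl on a double-bonded chain carbon bound to a double-bonded chain carbon. Nothing in the measured set isolates this exchange, so the step cannot be calibrated from the data at hand. Compound 4 is expected to sit close to compound 2, with the step of no change at the digits printed from compound 2 to compound 4 (within the scatter) estimated to stay within the scatter. The estimate for compound 4 in this assay is 10000 nM, with a range from 3000 nM to 35000 nM.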

Compound 4, concentration for 50% growth inhibition: 25000 nM
Compound 4: the middle estimate sits 2.5-fold (0.40 log units) below what was measured; low and high end bracket the measured number.
By their numbers in this assay, from the lowest: compounds 3 and 2 (each within the scatter of the next); then compound 4. At a limit, above all of these: compound 1.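

Among the compounds shown here, this pair gives the first readable step in the set. The two compounds differ only in the aromatic group on a double-bonded chain carbon bound to a double-bonded chain carbon. In this assay, 4-bromophenyl in place of 3,5-dimethylphenyl gives a 2.5-fold higher number from compound 2 to compound 4 (0.40 log units; beyond the scatter), a modest loss of growth inhibition, which shows that this position responds to a change of ring substituents even though both groups are six-membered aromatic carbon rings with no hydrogen-bond donors or acceptors and no net charge. Nothing measured in this set bears on why the number moves, so the step can be stated but not explained.

The exchange removes two methyl groups and adds a bromine in one move, so a single pair cannot show which of these matters, and it gives one direction at one position rather than a trend. It also leaves open how the sulfone series would respond to a quite different group at this place, such as a phenyl ring carrying an amine or a carboxylic acid.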